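From Benzyl to Aroylamino: A Step Without Precedent

A few compounds are considered here, and "the series" means these few. Any claim that something is new, unique, unknown or untested is made for them only; others in the source may bear on it.

compound 1 `C[C@H](NC(=O)c1c(Cc2ccc(C(C)(C)C)cc2)sc2c1CCOC2)c1ccc(C(=O)O)cc1` 9.5 nM
compound 2 `C[C@H](NC(=O)c1c(Cc2cccc(Cl)c2)sc2c1CCOC2)c1ccc(C(=O)O)cc1` 3.2 nM

In a functional assay on CHO/Galpha16 cells for antagonist activity at prostaglandin E2 receptor EP4 subtype (Homo sapiens), read by calcium flux, with a stated time of 15 min (a higher number here means a weaker inhibitor, a lower number a stronger inhibitor), compound 2 gives the lowest of the two numbers; the nearest is compound 1, and the step of a 3.0-fold lower number from compound 1 to compound 2 (0.47 log units; beyond the scatter) is modest. Compound 3 `C[C@H](NC(=O)c1c(NC(=O)c2ccc(F)cc2)sc2c1CCOC2)c1ccc(C(=O)O)cc1` differs from compound 2 by ((4-fluorophenyl)carbonyl)amino in place of 3-chlorobenzyl on an aromatic carbon. Within the data shown here, no measured step touches this linker: the only step, a 3.0-fold lower number from compound 1 to compound 2 (0.47 log units; beyond the scatter), swaps substituents on an otherwise unchanged benzyl group. The expected direction is therefore uncertain, and a modest weakening is estimated for compound 3, a 6.3-fold higher number from compound 2 to compound 3 (0.80 log units; beyond the scatter). Compound 3 is expected at 20 nM, with a range from 4 nM to 100 nM.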

Compound 3, half-maximal inhibitory concentration: > 1000 nM
Compound 3 ended at the assay's limit (the forecaster's own chance of this, stated with the estimate: 5%); middle value at least 50-fold (1.69 log units) from the limit.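

The earlier compounds shown here showed only a modest step between two benzyl groups. Exchanging the benzyl group itself on this aromatic carbon, next to the ring sulfur, gives an at least 310-fold higher number from compound 2 to compound 3 (2.49 log units; beyond the scatter), and likewise an at least 100-fold higher number from compound 1 to compound 3 (2.02 log units; beyond the scatter). Compound 3 stands at a limit of the assay and not at a number: the limit of > 1000 nM in this assay, at which 1 of the 3 values shown sits.

The link and the ring substituent change together here, so the compounds leave open which of them carries the loss. From the compounds shown here alone, whether a ((3-chlorophenyl)carbonyl)amino group or a simple amine on this carbon would stay near compound 2 remains open.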